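Swapping a dimethoxyphenyl for fluorophenyl in a urea series

The compounds below may be only part of what the source reports. "The series", "measured", "known", "first", "only" and "open" are said of these compounds alone.

Measured so far:
compound 1 `COc1ccc(OC)c(/C=N/NC(=O)Nc2ccc(Oc3ccnc(-c4nncn4CCN(C)C)c3)c(F)c2)c1` — "not determined" (no result reported)
compound 2 `COc1ccc(/C=N/NC(=O)Nc2ccc(Oc3ccnc(-c4nncn4CCN(C)C)c3)c(F)c2)c(OC)c1` — 6630 nM
compound 3 `COc1ccc(/C=N/NC(=O)Nc2ccc(Oc3ccnc(-c4nncn4CCN(C)C)c3)c(F)c2)c(OC)c1OC` — "not determined" (no result reported)

For the measured compounds named here, compound 2 holds the only number in this set; in an ADME assay on WI-38 cells (Homo sapiens) for cytotoxicity, read by MTT assay, with a stated time of 72 h (on this read-out lower numbers stand for stronger inhibition and higher numbers for weaker inhibition), compound 1 gives "not determined" (no result reported) and compound 3 gives "not determined" (no result reported), so compound 2 cannot be ranked against anything. In this assay compound 2 gives 6630 nM.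

Compound 4 `CN(C)CCn1cnnc1-c1cc(Oc2ccc(NC(=O)N/N=C/c3ccc(F)cc3)cc2F)ccn1` differs from compound 2 at one place: 4-fluorophenyl in place of 2,4-dimethoxyphenyl on a carbon with a double bond to nitrogen. Going by the values given here, no pair of measured compounds shows what such a change does here, so the step from compound 2 to compound 4 in this assay is expected to stay within the scatter, in no set direction; the expected step is a 1.1-fold higher number from compound 2 to compound 4 (0.02 log units; within the scatter). Compound 4 is therefore estimated at 7000 nM, with a likely range from 2500 nM to 20000 nM.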

Compound 4, half-maximal inhibitory concentration: 3980 nM
For compound 4 the middle estimate is 1.8-fold (0.25 log units) above the measured one; the range from low to high includes it.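

In this assay, the change at this position gives a 1.7-fold lower number from compound 2 to compound 4 (0.22 log units; within the scatter). For the compounds shown here, this is the first readable comparison in the set, and it shows that replacing 2,4-dimethoxyphenyl with 4-fluorophenyl on the carbon with a double bond to nitrogen does not clearly separate the two compounds. Nothing measured here explains this result.

Going by these compounds, whether an amine or a carboxylic acid on the phenyl ring at this position would move the number beyond the scatter remains open. So does whether a longer chain there would do so.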